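The compounds below may be only part of what the source reports. "The series", "measured", "known", "first", "only" and "open" are said of these compounds alone.

Measured so far:
Compound 1 `CCN1CCN(C(=O)c2ccc(Nc3ncc4c(n3)N(C)C(=O)N(c3cc(NC(=O)c5cccc(C(F)(F)F)c5)ccc3C)C4)cn2)CC1`: 728 nM
Compound 2 `Cc1ccc(Nc2ncc3c(n2)N(C)C(=O)N(c2cc(NC(=O)c4ccc(CN5CCC(N(C)C)C5)c(C(F)(F)F)c4)ccc2C)C3)cn1`: 636 nM

Both compounds were tested in an ADME assay on BaF3 cells (Mus musculus) for inhibition, read by CellTiter-Glo, with a stated time of 72 h; a lower number here means a stronger inhibitor of growth, a higher number a weaker inhibitor of growth. Compound 2, at 636 nM, stands level with compound 1: their two numbers lie within the usual scatter of repeated measurements, so neither can be called the stronger inhibitor.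

Compound 3 `CCN1CCN(C(=O)c2ccc(Nc3ncc4c(n3)N(C)C(=O)N(c3cc(NC(=O)c5ccc(CN6CCC(N(C)C)C6)c(C(F)(F)F)c5)ccc3C)C4)cn2)CC1` is compound 2 with one change: (4-ethylpiperazin-1-yl)carbonyl in place of methyl on an aromatic carbon. In words, (4-ethylpiperazin-1-yl)carbonyl stands in place of methyl on an aromatic carbon. Among the compounds with values here, no measured pair isolates this change. Compound 1 carries the same (4-ethylpiperazin-1-yl)carbonyl and gives 728 nM, which is within the scatter of the value for compound 2, so no shift beyond the scatter is expected in this assay. The estimate amounts to an expected 1.1-fold lower number from compound 2 to compound 3 (0.03 log units; within the scatter). For compound 3 the expected value is 600 nM, with an estimated range of 200 nM to 1800 nM.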

Compound 3, concentration for 50% growth inhibition: 704 nM
For compound 3 the middle estimate is 1.2-fold (0.07 log units) below the measured one; measured number inside the range.
By their numbers in this assay, from the lowest: compounds 2, 3 and 1 (each within the scatter of the next).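

Putting the much larger (4-ethylpiperazin-1-yl)carbonyl in place of methyl, on the aromatic carbon next to the ring nitrogen, gives in this assay a 1.1-fold higher number from compound 2 to compound 3 (0.04 log units; within the scatter), so this position takes the larger group with no shift beyond the scatter. The second pair shows the same for the other site: (3-(dimethylamino)pyrrolidin-1-yl)methyl in place of hydrogen gives a 1.0-fold lower number from compound 1 to compound 3 (0.01 log units; within the scatter), and this holds with the (4-ethylpiperazin-1-yl)carbonyl already present. Nothing measured here offers a reason for either result.

The compounds shown leave open whether another group at this position, such as a primary amine or a carboxylic acid, would move the number beyond the scatter. They also leave open which part of these molecules, if any, can change that number in this assay.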